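A few compounds are considered here, and "the series" means these few. Any claim that something is new, unique, unknown or untested is made for them only; others in the source may bear on it.

Working notes on the series. In a physicochemical assay, read by spectrophotometry, with a stated time of 30 min (a higher number here means a weaker inhibitor, a lower number a stronger inhibitor), compound 1 (`O=[N+]([O-])c1cccc(Cn2cc(COc3ccc(Cl)cc3)nn2)c1`) gives 21.3 ug/mL and compound 2 (`Clc1ccc(Cn2cc(COc3ccc(Cl)cc3)nn2)cc1`) gives 26.1 ug/mL. Going by the values given here, these two values lie within the usual scatter of each other, so the numbers so far do not separate compound 2 from compound 1.

Compound 3 (`Clc1ccc(OCc2cn(Cc3cccc(Cl)c3)nn2)cc1`) has not yet been measured. It carries 3-chlorophenyl in place of 4-chlorophenyl on a saturated chain carbon bound to an aromatic nitrogen. Among the compounds with values here, no step between measured compounds is available to size this change, so the expectation stays close to compound 2 at 26.1 ug/mL, with no direction favoured. The expected change is none beyond the scatter, estimated as a 1.1-fold lower number from compound 2 to compound 3 (0.04 log units; within the scatter). For compound 3 the estimated value in this assay is 24 ug/mL, with an expected range of 12 ug/mL to 48 ug/mL.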

Compound 3, half-maximal inhibitory concentration: 23.3 ug/mL
Compound 3: the middle estimate sits 1.0-fold (0.01 log units) above what was measured, and the stated range covers the measured number.
By their numbers in this assay, from the lowest: compounds 1, 3 and 2 (each within the scatter of the next).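

In this assay, 3-chlorophenyl in place of 4-chlorophenyl on a saturated chain carbon bound to an aromatic nitrogen gives a 1.1-fold lower number from compound 2 to compound 3 (0.05 log units; within the scatter), so this place has now been tested with the same group in two arrangements, and the change does not separate the two compounds. Chloro in place of nitro on an aromatic carbon gives a 1.1-fold higher number from compound 1 to compound 3 (0.04 log units; within the scatter), the first single-place reading of that swap, and it too does not separate the compounds. No measurement is available that would explain either step.

The compounds shown leave open whether any change at this place can move the number beyond the scatter, for example an amine or a carboxylic acid in place of chloro. They also leave open what a longer chain in place of the saturated chain carbon would do.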